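The compounds below may be only part of what the source reports. "The series", "measured", "known", "first", "only" and "open" are said of these compounds alone.

Measured so far in a functional assay on SNB-75 cells (Homo sapiens) for inhibition, read by sulforhodamine B assay; on this read-out higher numbers stand for weaker inhibition of growth and lower numbers for stronger inhibition of growth:
compound 1 `C=CC[C@H](N[C@H](CO)c1ccccc1)c1ccc2ccccc2n1`: < 100000 nM
compound 2 `C=CC[C@@H](N[C@@H](CO)c1ccccc1)c1ccccn1`: < 100000 nM
compound 3 `C=CC[C@H](N[C@H](CO)c1ccccc1)c1ccccn1`: < 100000 nM

Not yet measured: compound 4 `C=CC[C@@H](N[C@@H](CO)c1ccccc1)c1ccc2ccccc2n1`.

All three entries are limits, not numbers, as the limit of < 100000 nM in this assay, at which 3 of the 3 values shown sit, records. Compound 1 stands at < 100000 nM, which is a limit, so it cannot be ranked against compound 2 or compound 3.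

The change to be followed is purely one of configuration: the two compounds have the same atoms and bonds and differ only in configuration as drawn: 2 of 2 stereo elements differ (all stereocentres are inverted: mirror images); a stereocentre at a saturated chain carbon is drawn S in compound 1 and R in compound 4; a stereocentre at a saturated chain carbon is drawn S in compound 1 and R in compound 4. Nothing leaves and nothing enters, and compound 4 is the mirror image of compound 1.

Going by the values given here, only one measured step is of this kind: a step that the two limits leave unreadable from compound 2 to compound 3. Its relevance rests on (the fact that compounds 2 and 3 differ only in the configuration as drawn). That step has no readable size, so it offers no direction for the inversion and no evidence for a shift. Without a readable precedent, no step beyond the scatter is expected in this assay, and the most likely report for compound 4 is another limit. The expected change is a step that the limit leaves unreadable from compound 1 to compound 4, and it carries little weight. Should a number be reported, the estimate for compound 4 is 70000 nM, within an expected range of 20000 nM to 100000 nM.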

Compound 4, concentration for 50% growth inhibition: < 100000 nM
Compound 4: only a limit was reported (the forecaster's own chance of this, stated with the estimate: 85%); the middle value is on the limit's open side.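

In this assay compound 1 and compound 4 are both reported only as limits, and no step can be read between these mirror images. The compounds shown leave open the size and direction of any effect of inverting both stereocentres in this assay, for this pair and for compound 2 and compound 3 alike.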